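The source may report more compounds than this note shows. Statements on the series, on what has been measured and on what is new or still open speak of the compounds shown alone.

Values in a functional assay on MDBK cells (Bos taurus) for cytotoxicity; on this read-out lower numbers stand for higher toxicity in this test and higher numbers for lower toxicity in this test:
Compound 1 `C=CCO/N=C(\C#N)C(=O)NCC1=NOC(c2ccccc2)C1`: 100 ug/mL
Compound 2 `C=CCO/N=C(\C#N)C(=O)NCC1=NOC(c2ccccc2)(c2ccccc2)C1`: 100 ug/mL
Compound 3 `CCO/N=C(\C#N)C(=O)NCC1=NOC(C(C)(C)C)C1`: > 100 ug/mL

Compound 3 reads > 100 ug/mL, which is a limit of the assay and not a number.

Compound 4 `CC(C)(C)C1CC(CNC(=O)/C(C#N)=N/OCC#N)=NO1` departs from compound 3 by cyano in place of methyl on a saturated chain carbon bound to an oxygen on an unsaturated carbon, or ethoxy to cyanomethoxy. Among the measured compounds shown here, only one measured step is available, no change at the digits printed from compound 1 to compound 2 (within the scatter), and it is a different change: phenyl in place of hydrogen on a saturated ring carbon. For the measured compounds named here, it therefore bears on the present change only loosely, and no measured step covers the exchange of ethoxy for cyanomethoxy.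

Resting on that single step, no change at the digits printed from compound 1 to compound 2 (within the scatter), no move beyond the scatter is expected in this assay, in either direction. The expected step is a number no higher from compound 3 to compound 4 (the limit leaves the size open). For compound 4 the estimate is 100 ug/mL, with an expected range of 40 ug/mL to 200 ug/mL.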

Compound 4, half-maximal cytotoxic concentration: > 100 ug/mL
Compound 4: no number, only a limit; the forecaster's own chance of this, stated with the estimate: 60%; the middle value sits exactly at the limit.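

In this assay no step can be read from compound 3 to compound 4, because each carries only a limit of the assay and not a number: the limit of > 100 ug/mL in this assay, at which 2 of the 4 values shown sit.
On these data alone, whether cyanomethoxy in place of ethoxy changes toxicity in this test, and in which direction, stays open.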